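The source may hold more compounds than are shown below. What is called first, only, known or untested is meant among the compounds shown, and "the series" means these compounds.

Compound 1 `Cc1cccc(NC(=O)N[C@H](C)c2ccccc2)c1` gives the lowest number of the three measured compounds in an ADME assay on the whole organism with Oryza sativa as the target, tested at 10 uM (on this read-out higher numbers stand for a weaker effect at the one concentration tested and lower numbers for a stronger effect), with compound 1 at 47%. Compound 2 `Cc1cccc(NC(=O)N[C@@H](C)c2ccccc2)c1`, in this assay, gives 100%, and compound 3 `CCc1ccccc1NC(=O)N[C@@H](C)c1ccccc1` gives 95%. Among the measured compounds shown here, the only single-change step measured, a number 53 percentage points higher from compound 1 to compound 2 (beyond the scatter), rests on the fact that compounds 1 and 2 differ only in the configuration as drawn and says nothing about a change on the ring. Compound 4 `C[C@@H](NC(=O)Nc1cccc(F)c1)c1ccccc1` differs from compound 1 by fluoro in place of methyl on an aromatic carbon. For the measured compounds named here, no measured step bears on this exchange, so the expectation is little movement, with a wide margin. Compound 4 is expected to give about 60%, between 35% and 95%, in this assay. This estimate means a step of a number 13 percentage points higher from compound 1 to compound 4 (beyond the scatter) that is expected to stay near the scatter.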

Compound 4, a percentage reported as activity, at one concentration (the size of the read-out at that concentration, not a potency): 84%
Estimate against measurement, compound 4: 24 percentage points below; measured number inside the range.
By their numbers in this assay, from the lowest: compound 1; then compound 4; then compounds 3 and 2 (each within the scatter of the next).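

Fluoro in place of methyl on this aromatic carbon is no silent exchange in this assay, where the result is a number 37 percentage points higher from compound 1 to compound 4 (beyond the scatter) and a higher number stands for a weaker effect. The ring substituent therefore matters as well as the configuration at the chain carbon, and at this place methyl goes with the stronger effect. Nothing measured here explains this step.

Going by these compounds, whether chloro, methoxy or a longer chain at this place would stay close to methyl or to fluoro remains open. So does whether this exchange would move the number similarly in the opposite configuration.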